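Phenyl Ester to Fluorobenzyl Ester in a Kinase Assay

The source may report more compounds than this note shows. Statements on the series, on what has been measured and on what is new or still open speak of the compounds shown alone.

Compound 1 `CCOC(=O)c1c(-c2ccc(OC)c(OC)c2)csc1NC` was tested in an assay on isolated protein for inhibition of protein kinase C zeta type (Homo sapiens), with stated times of 1 h and 2.5 min, tested at 30 uM (a higher number here means more inhibition at the concentration tested (going by the name of the read-out), a lower number less inhibition), and gave 32%. Compound 2 `COc1ccc(-c2csc(N)c2C(=O)Oc2ccccc2)cc1OC` gave 48% in this assay, the higher of the two numbers, and its gap to compound 1 lies beyond the usual scatter. Compound 3 `COc1ccc(-c2csc(N)c2C(=O)OCc2ccc(F)cc2)cc1OC` differs from compound 2 in one place: 4-fluorobenzyl in place of phenyl on an oxygen next to a carbonyl group. Among the compounds with values here, no measured pair shows this change, so the expectation rests on compound 2 alone, with a step of a number 3 percentage points lower from compound 2 to compound 3 (within the scatter) expected to stay within the scatter. Compound 3 is estimated at 45%, with a range from 20% to 70%.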

Compound 3, a percentage reported as inhibition, at one concentration (the size of the read-out at that concentration, not a potency): 2%
The estimate for compound 3 lay 43 percentage points above the measured number; measured number outside the range, below it.
By their numbers in this assay, from the lowest: compound 3; then compound 1; then compound 2.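

In this assay, 4-fluorobenzyl in place of phenyl on an oxygen next to a carbonyl group gives a number 46 percentage points lower from compound 2 to compound 3 (beyond the scatter) and so shows that this position is sensitive to the group it carries. A change of only a few atoms here can separate clear inhibition from almost none at the concentration tested. Nothing shown accounts for this loss.

The change combines a fluorine with a benzyl group, so either could go with the loss. Plain benzyl and 4-fluorophenyl groups would separate the two, while a carboxylic acid or an amide at this place remains an open question.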